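From chloro to bromo under a cytotoxicity limit

The source may hold more compounds than are shown below. What is called first, only, known or untested is meant among the compounds shown, and "the series" means these compounds.

Compound 1, `C=C1C[C@]23C[C@@]1(O)CC[C@H]2c1ccc(O)c(C)c1[C@@H]3Cn1cc(-c2ccc(C)cc2)nn1`: in a functional assay on MCF7 cells (Homo sapiens) for cytotoxicity, read by MTT assay, with a stated time of 4 days (a lower number here means a stronger inhibitor, a higher number a weaker inhibitor), compound 1 gives > 20000 nM, a limit of the assay rather than a number.
Compound 2, `C=C1C[C@]23C[C@@]1(O)CC[C@H]2c1ccc(O)c(C)c1[C@@H]3Cn1cc(-c2ccc(Cl)cc2)nn1`: in this assay compound 2 gives > 20000 nM, again a limit.

Compound 2 therefore stands at the top of what this assay reports, with no number of its own; (the limit of > 20000 nM in this assay, at which 2 of the 2 values shown sit). Among the measured compounds shown here, the step that the two limits leave unreadable from compound 1 to compound 2 is unreadable, as both of its ends are limits, so the one measured change on this aromatic carbon gives no size to lean on.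

Compound 3, `C=C1C[C@]23C[C@@]1(O)CC[C@H]2c1ccc(O)c(C)c1[C@@H]3Cn1cc(-c2ccc(Br)cc2)nn1`, differs from compound 2 by bromo in place of chloro on an aromatic carbon. For the measured compounds named here, no measured step bears on this change with a readable size, and nothing here points to a shift beyond the scatter in either direction in this assay. Compound 3 is expected to give 30000 nM, within 12000 nM to 100000 nM. The step that the limit leaves unreadable from compound 2 to compound 3 is expected to stay hidden under the assay limit.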

Compound 3, half-maximal inhibitory concentration: > 20000 nM
Compound 3: no number, only a limit; the forecaster's own chance of this, stated with the estimate: 85%; the middle value lies beyond the limit too.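

Compound 3, like compound 1 and compound 2, reaches only a limit in this assay, so no step among the three can be read: the limit of > 20000 nM in this assay, at which 3 of the 3 values shown sit.

The compounds shown leave open whether any group at this place on the aromatic ring would give a measurable value in this assay.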